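Swapping tert-butyl for nitro on a urea-bearing aryl ring

A few compounds are considered here, and "the series" means these few. Any claim that something is new, unique, unknown or untested is made for them only; others in the source may bear on it.

Compound 1 `O=C(Nc1ccc([N+](=O)[O-])cc1)Nc1cccc(CNc2ncnc3ccccc23)c1`: > 50000 nM
Compound 2 `COc1cc2ncnc(NCc3cccc(NC(=O)Nc4ccc(C(C)(C)C)cc4)c3)c2cc1OC`: 5210 nM

Of the compounds shown here, two have been measured in a functional assay on A549 cells (Homo sapiens) for antiproliferative activity, read by MTT assay; a higher number here means a weaker inhibitor, a lower number a stronger inhibitor. Compound 1 `O=C(Nc1ccc([N+](=O)[O-])cc1)Nc1cccc(CNc2ncnc3ccccc23)c1` shows no measurable inhibition; its value of > 50000 nM is a limit of the assay, not a number. Compound 2 `COc1cc2ncnc(NCc3cccc(NC(=O)Nc4ccc(C(C)(C)C)cc4)c3)c2cc1OC` gives 5210 nM in this assay and so stands as the only real number shown, the other value being (the limit of > 50000 nM in this assay, at which 1 of the 2 values shown sits).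

Compound 3 `COc1cc2ncnc(NCc3cccc(NC(=O)Nc4ccc([N+](=O)[O-])cc4)c3)c2cc1OC` differs from compound 2 in one place: nitro in place of tert-butyl on an aromatic carbon. Compound 3 shares its nitro-bearing urea end with compound 1 and its dimethoxy-bearing core with compound 2. Among the compounds with values here, no step between measured compounds is known, so there is no direct precedent for this change. Within the data shown here, since the only compound carrying the nitro group, compound 1, sits at the assay limit, a loss of potency beyond the scatter is expected, as step a 4.8-fold higher number from compound 2 to compound 3 (0.68 log units; beyond the scatter). Compound 3 is therefore estimated at 25000 nM, with a likely range from 8000 nM to 80000 nM.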

Compound 3, half-maximal inhibitory concentration: > 50000 nM
Compound 3 was reported as a limit; the forecaster's own chance of this, stated with the estimate: 40%; at least 2.0-fold (0.30 log units) between middle value and limit.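

In this assay, putting nitro in place of tert-butyl on this aromatic carbon, para to a large group, gives an at least 9.5-fold higher number from compound 2 to compound 3 (0.98 log units; beyond the scatter). This is the first comparison shown in which only this one group changes, which compound 1 and compound 2 could not offer because they differ in more than one place. Compound 3 is reported only as a limit, not a number, so the step sets a minimum for the loss and its full size stays unknown: the limit of > 50000 nM in this assay, at which 2 of the 3 values shown sit.

The compounds shown cannot separate the loss of tert-butyl from the arrival of nitro, and no property of either group is measured here. On the same core, an amine or a plain hydrogen on this carbon would help tell these two readings apart.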